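The source may hold more compounds than are shown below. What is called first, only, known or untested is meant among the compounds shown, and "the series" means these compounds.

Three compounds have been tested in a functional assay on IGROV-1 cells (Homo sapiens) for cytotoxicity, read by sulforhodamine B assay, with a stated time of 48 h; a lower number here means a stronger inhibitor of growth, a higher number a weaker inhibitor of growth:

Compound 1 `ClCc1ccc(Cn2cnc3c(Cl)ncnc32)cc1` gives 25100 nM.
Compound 2 `Nc1nc(Cl)c2ncn(Cc3ccc(CCl)cc3)c2n1` gives 22900 nM.
Compound 3 `ClCc1ccccc1Cn1cnc2c(Cl)ncnc21` gives 8910 nM.

Compound 1 and compound 2 share a core and differ in one place, (amino in place of hydrogen on an aromatic carbon), and that change moved the read-out by a 1.1-fold lower number from compound 1 to compound 2 (0.04 log units; within the scatter), so the two numbers cannot be told apart. Compound 3 has the same atoms as compound 1 joined differently; the difference between the two cores is not broken down here. Its number is the lowest of the three, and the gaps to compound 2 and compound 1 both lie beyond the scatter.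

Compound 4 `Nc1nc(Cl)c2ncn(Cc3ccccc3CCl)c2n1` is not yet measured. It stands to compound 3 as compound 2 stands to compound 1: the change is amino in place of hydrogen on an aromatic carbon, at a place described in the same words. Because that same change produced only a 1.1-fold lower number from compound 1 to compound 2 (0.04 log units; within the scatter), the step from compound 3 to compound 4 is expected to be about as small, roughly a 1.1-fold lower number from compound 3 to compound 4 (0.05 log units; within the scatter). On that basis compound 4 is expected to give about 8000 nM in this assay, most likely between 4000 nM and 17000 nM.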

Compound 4, concentration for total growth inhibition: > 100000 nM
Compound 4: no number, only a limit; the forecaster's own chance of this, stated with the estimate: 5%; middle value at least 12-fold (1.09 log units) from the limit.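

In this assay compound 4 gives > 100000 nM, which is a limit of the assay and not a number. Even read as a limit, amino in place of hydrogen on an aromatic carbon gives an at least 11-fold higher number from compound 3 to compound 4 (1.05 log units; beyond the scatter), so in this series the result of the change on one core does not predict its result on the other: the same change on two cores in this assay, a 1.1-fold lower number (0.04 log units; within the scatter) from compound 1 to compound 2 and an at least 11-fold higher number (1.05 log units; beyond the scatter) from compound 3 to compound 4, at least 12-fold (1.08 log units) apart, beyond the scatter of two such steps This does not show the true size of the step, nor why the two cores respond so differently, and it rests on only two pairs of compounds, too few to support a general rule.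

The compounds shown leave open whether other groups at the same place, between two ring nitrogen atoms, such as a methylamino group or a hydroxyl group, would also separate the two cores in this way. They also leave open whether the contrast would persist with a methoxy group in place of the chloro group.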